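Ethoxy replaces methoxy(methyl)amino on the carbonyl carbon

The source may hold more compounds than are shown below. What is called first, only, known or untested is meant among the compounds shown, and "the series" means these compounds.

Of the compounds shown here, two have numbers so far. In a functional assay on MDA-MB-231 cells (Homo sapiens) for antiproliferative activity (on this read-out higher numbers stand for weaker inhibition of growth and lower numbers for stronger inhibition of growth), compound 1 `CCOC(=O)C[C@H]1[C@@H](O[Si](C)(C)C(C)(C)C)[C@H](n2cnc3c(NC(=O)Nc4ccccc4)ncnc32)O[C@@H]1COC(=O)NC` gives 17.5 nM and compound 2 `CNC(=O)NC[C@H]1O[C@@H](n2cnc3c(NC(=O)Nc4ccccc4)ncnc32)[C@H](O[Si](C)(C)C(C)(C)C)[C@@H]1CC(=O)N(C)OC` gives 12.3 nM; the two values lie within the scatter of each other, so compound 2 is not separated from compound 1 on this assay. Compound 3 `CCOC(=O)C[C@H]1[C@@H](O[Si](C)(C)C(C)(C)C)[C@H](n2cnc3c(NC(=O)Nc4ccccc4)ncnc32)O[C@@H]1CNC(=O)NC` differs from compound 2 by ethoxy in place of methoxy(methyl)amino on a carbonyl carbon. Within the data shown here, no measured pair shows this change, so the step is expected to be small, in either direction or none beyond the scatter, giving an estimated 1.2-fold higher number from compound 2 to compound 3 (0.09 log units; within the scatter). Compound 3 is therefore expected to give about 15 nM, between 7 nM and 35 nM.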

Compound 3, concentration for 50% growth inhibition: 3.96 nM
For compound 3 the middle estimate is 3.8-fold (0.58 log units) above the measured one, and the stated range ends above it.
By their numbers in this assay, from the lowest: compound 3; then compounds 2 and 1 (each within the scatter of the next).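

In this assay the step of a 3.1-fold lower number from compound 2 to compound 3 (0.49 log units; beyond the scatter) comes with ethoxy in place of methoxy(methyl)amino on the carbonyl carbon, and the step of a 4.4-fold lower number from compound 1 to compound 3 (0.65 log units; beyond the scatter) comes with (methylcarbamoyl)amino in place of (methylcarbamoyl)oxy on the saturated chain carbon. Each place therefore responds to a change made there alone, which compound 1 and compound 2, differing in two places, could not show. No data on hand account for either step. Still open, on these data alone, is how the carbonyl carbon behaves with a carboxylic acid or a longer alkoxy chain in place of the ester.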